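Working notes: nitro in place of fluoro on compound 2

The compounds below may be only part of what the source reports. "The series", "measured", "known", "first", "only" and "open" are said of these compounds alone.

Measured in a functional assay on A549 cells (Homo sapiens) for antiproliferative activity, read by MTT assay, with a stated time of 72 h; on this read-out higher numbers stand for weaker inhibition and lower numbers for stronger inhibition:
- compound 1 `CC(=O)N(C)c1ccc2[nH]c(-c3n[nH]c4ccccc34)cc2n1` gives > 50000 nM as a limit of the assay
- compound 2 `CN(C(=O)c1ccc(F)cc1)c1ccc2[nH]c(-c3n[nH]c4ccccc34)cc2n1` gives 9650 nM
- compound 3 `CN(C(=O)c1ccc(Cl)cc1)c1ccc2[nH]c(-c3n[nH]c4ccccc34)cc2n1` gives 2220 nM

Compound 2 holds the higher of the two numeric values, and compound 3 is its nearest neighbour. Compound 4 `CN(C(=O)c1ccc([N+](=O)[O-])cc1)c1ccc2[nH]c(-c3n[nH]c4ccccc34)cc2n1` has nitro in place of fluoro on an aromatic carbon, para to a large group (nitro in place of fluoro on an aromatic carbon). The closest measured change is chloro in place of fluoro, a modest step (a 4.3-fold lower number from compound 2 to compound 3 (0.64 log units; beyond the scatter)). The steps from methyl to a substituted phenyl are larger (an at least 5.1-fold lower number from compound 1 to compound 2 (0.71 log units; beyond the scatter)) (an at least 22-fold lower number from compound 1 to compound 3 (1.35 log units; beyond the scatter)) but start from a limit and concern a different change. A modest move to a lower number in this assay is therefore expected, on thin evidence. The expected step is a 2.4-fold lower number from compound 2 to compound 4 (0.38 log units; beyond the scatter) on this estimate. For compound 4 the estimated value is 4000 nM (expected range 900 nM to 20000 nM).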

Compound 4, half-maximal inhibitory concentration: 34500 nM
For compound 4 the middle estimate is 8.6-fold (0.94 log units) below the measured one, and the stated range ends below it.
By their numbers in this assay, from the lowest: compound 3; then compound 2; then compound 4. At a limit, above all of these: compound 1.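

In this assay the replacement of fluoro on an aromatic carbon, para to a large group, does not run in one direction: nitro moves the number up (a 3.6-fold higher number from compound 2 to compound 4 (0.55 log units; beyond the scatter)), opposite to the chloro step (a 4.3-fold lower number from compound 2 to compound 3 (0.64 log units; beyond the scatter)). The choice of group at this position therefore matters widely (a 16-fold higher number from compound 3 to compound 4 (1.19 log units; beyond the scatter)), and the chloro result does not carry over to nitro. The remaining step starts from a limit and its floor lies within the scatter (an at least 1.4-fold lower number from compound 1 to compound 4 (0.16 log units; that floor lies within the scatter)), so it sets no order between the two: the limit of > 50000 nM in this assay, at which 1 of the 4 values shown sits.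

On these data alone, whether an amine or a methoxy group at this position would fall nearer chloro or nitro stays open. The compounds shown also leave open whether a carboxylic acid here would follow nitro.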